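Aryl versus methyl on the hydroxy-bearing chain carbon

The source may hold more compounds than are shown below. What is called first, only, known or untested is meant among the compounds shown, and "the series" means these compounds.

Compound 3 `CC(O)CCn1nc2c(Br)c(Br)c(Br)c(Br)c2n1` carries a methyl on the saturated chain carbon bound to an oxygen on a saturated carbon and a saturated chain carbon. For the measured compounds named here, in a functional assay on CCRF-CEM cells (Homo sapiens) for antiproliferative activity, read by MTT assay, with a stated time of 24 h, tested at 50 uM (a lower number here means a stronger effect, a higher number a weaker effect of the compound at the concentration tested), compound 3 gives 89%, the highest of the three numbers measured so far and therefore the weakest effect in this set. Compound 1 `OC(CCn1nc2c(Br)c(Br)c(Br)c(Br)c2n1)c1ccc(F)cc1` gives 46% in this assay, and compound 2 `COc1cccc(C(O)CCn2nc3c(Br)c(Br)c(Br)c(Br)c3n2)c1` gives 58%. Within the aryl pair the step is a number 12 percentage points higher from compound 1 to compound 2 (beyond the scatter). Going from an aryl group to methyl, the steps are a number 43 percentage points higher from compound 1 to compound 3 (beyond the scatter) and a number 31 percentage points higher from compound 2 to compound 3 (beyond the scatter).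

Compound 4 `OC(CCn1nc2c(Br)c(Br)c(Br)c(Br)c2n1)c1ccc(Cl)cc1` differs from compound 3 in one place: 4-chlorophenyl in place of methyl on a saturated chain carbon bound to an oxygen on a saturated carbon and a saturated chain carbon. This runs opposite to the two large measured steps that replaced an aryl group by methyl, a number 43 percentage points higher from compound 1 to compound 3 (beyond the scatter) and a number 31 percentage points higher from compound 2 to compound 3 (beyond the scatter), and the 4-chlorophenyl is closest in kind to the 4-fluorophenyl of compound 1, whose value is 46%. A large step downward in this assay is therefore expected, a number 43 percentage points lower from compound 3 to compound 4 (beyond the scatter), putting compound 4 near compound 1 rather than compound 2. For compound 4 the estimate in this assay is 46%, with a range from 32% to 62%.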

Compound 4, a percentage reported as activity, at one concentration (the size of the read-out at that concentration, not a potency): 56%
Beside the measured number, compound 4's estimate is 10 percentage points below it, within the range that was stated.
By their numbers in this assay, from the lowest: compounds 1, 4 and 2 (each within the scatter of the next, the first and the last beyond it); then compound 3.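

In this assay the 4-chlorophenyl group in place of methyl gives a number 33 percentage points lower from compound 3 to compound 4 (beyond the scatter) and is the third aryl group at this saturated chain carbon to stand clear of methyl, so among the compounds shown, compound 3 is the only one with methyl and the only one beyond the scatter from all the others. Chloro in place of fluoro on an aromatic carbon gives a number 10 percentage points higher from compound 1 to compound 4 (within the scatter) and 4-chlorophenyl in place of 3-methoxyphenyl gives a number 2 percentage points lower from compound 2 to compound 4 (within the scatter), so neither change is resolved by this read-out, and the gap between compound 1 and compound 2 does not sort into a simple halogen-against-methoxy difference. No measurement shown bears on why an aryl group at this carbon separates from methyl.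

As far as these compounds go, it remains open whether an aromatic ring is needed here at all, or whether a cyclohexyl ring or a longer chain such as butyl in place of methyl would give a similar number. Also open is what an amine in place of the oxygen on this carbon would do, and a reading at a single concentration gives no potency for any of these compounds.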